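The source may report more compounds than this note shows. Statements on the series, on what has been measured and on what is new or still open speak of the compounds shown alone.

Compound 2 `COc1ccccc1C1C(C#N)=C(N)N(c2ccc(S(N)(=O)=O)cc2)C2=C1CCCC2` is the point of departure. In a functional assay on Ehrlich cells (Mus musculus) for cytotoxicity, read by trypan blue exclusion, with a stated time of 2 h, tested at 10 ug/mL (on this read-out higher numbers stand for a stronger effect at the one concentration tested and lower numbers for a weaker effect), compound 2 gives 30%, the highest of the three numbers recorded, and its steps to both other compounds lie beyond the scatter. Among the compounds with values here, its nearest neighbour is compound 1 `N#CC1=C(N)N(c2ccc(S(N)(=O)=O)cc2)C2=C(CCCC2)C1c1ccccc1O`, which in this assay gives 10%; the step of a number 20 percentage points higher from compound 1 to compound 2 (beyond the scatter) is the only single-point change among the measured compounds. Furthest is compound 3 `COc1ccc(C2C(C#N)=C(N)N(c3ccc(S(N)(=O)=O)cc3)C3=C2CCCC3)c2ccccc12`, for which this assay gives 0%; no single-place step links compound 3 to compound 2, so its value only shows how far down the set reaches.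

Compound 4 `Cc1ccc(C2C(C#N)=C(N)N(c3ccc(S(N)(=O)=O)cc3)C3=C2CCCC3)o1` is not yet measured. It differs from compound 2 in this way: 5-methylfuran-2-yl in place of 2-methoxyphenyl on a saturated ring carbon. Within the data shown here, the one measured step, from compound 1 to compound 2, concerns a methyl on an aromatic oxygen and does not speak to an exchange of the whole aromatic group, so no measured step bears directly on the change to compound 4. With all three recorded numbers low and the two variants of the aromatic group other than that in compound 2 lower, a modest fall, or no step beyond the scatter, is expected; the step of a number 15 percentage points lower from compound 2 to compound 4 (beyond the scatter) is the estimate. Compound 4 is therefore expected to give 15% in this assay, within a range from 0% to 35%.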

Compound 4, a percentage reported as activity, at one concentration (the size of the read-out at that concentration, not a potency): 0%
Beside the measured number, compound 4's estimate is 15 percentage points above it; measured number inside the range.
By their numbers in this assay, from the lowest: compounds 3, 4 and 1 (each within the scatter of the next); then compound 2.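

Within the data shown here, this is the first measured change at the saturated ring carbon, and it shows that the whole aromatic group there can shift the read-out: putting 5-methylfuran-2-yl in place of 2-methoxyphenyl gives a number 30 percentage points lower from compound 2 to compound 4 (beyond the scatter) in this assay. The earlier step concerned only a methyl on an aromatic oxygen, whereas this one exchanges a six-membered aromatic ring of carbon only for a five-membered aromatic ring with 1 hetero atom. The other exchange at this carbon, 5-methylfuran-2-yl in place of 2-hydroxyphenyl, gives a number 10 percentage points lower from compound 1 to compound 4 (within the scatter), so the read-out does not separate those two groups, and among the compounds compared here only the 2-methoxyphenyl group of compound 2 stands apart; nothing measured on these compounds explains this difference.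

From the compounds shown here alone, it remains open whether an unsubstituted phenyl, a thiophen-2-yl or a cyclohexyl group on this saturated ring carbon would match compound 2 at 30% or fall to the level of compound 4 at 0%. Going by these compounds, it is also open whether an ethoxy or a dimethylamino group in place of the methoxy group of compound 2 would carry the read-out further.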